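Chain amine variant of the tetracyclic N-oxide series

The source may report more compounds than this note shows. Statements on the series, on what has been measured and on what is new or still open speak of the compounds shown alone.

Measured compounds in a toxicity assay on L02 cells (Homo sapiens) for cytotoxicity, read by MTT assay, with a stated time of 72 h; a lower number here means a stronger inhibitor, a higher number a weaker inhibitor:
compound 1 `O=C1c2c[n+]([O-])c3ccccc3c2C(=O)c2c1c1ccccc1n2Cc1cn([C@@H]2C[C@H](O)[C@@H](CO)O2)nn1` gives 630 nM
compound 2 `O=C1c2c[n+]([O-])c3ccccc3c2C(=O)c2c1c1ccccc1n2CCCCN1CCCCC1` gives 610 nM
compound 3 `CC1(C)OC[C@@H](Cn2cc(Cn3c4c(c5ccccc53)C(=O)c3c[n+]([O-])c5ccccc5c3C4=O)nn2)O1` gives 2900 nM

Compound 2 carries the lowest of the three numbers in this assay; the gap to compound 1 is within the scatter, so the two are not ordered, while compound 3 stands clearly higher. Among the measured compounds shown here, the only step between two measured compounds, a 4.6-fold higher number from compound 1 to compound 3 (0.66 log units; beyond the scatter), concerns the substituent on the aromatic nitrogen and not the chain amine, so it has no direct bearing on the change considered here.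

Compound 4 `CN(C)CCCCCn1c2c(c3ccccc31)C(=O)c1c[n+]([O-])c3ccccc3c1C2=O` is not yet measured. It differs from compound 2 by (dimethylamino)methyl in place of piperidin-1-yl on a saturated chain carbon, four bonds along the chain from an aromatic nitrogen. The nitrogen on the chain stays in place and the chain length is unchanged; only the substituents on that nitrogen differ. For the measured compounds named here, no measured pair shows this kind of exchange, so nothing in the data argues for a shift beyond the scatter. Compound 4 is therefore expected to give 700 nM in this assay, within 300 nM to 1600 nM, a step of a 1.1-fold higher number from compound 2 to compound 4 (0.06 log units; within the scatter) that is estimated to stay inside the usual scatter.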

Compound 4, half-maximal inhibitory concentration: 240 nM
Estimate against measurement, compound 4: 2.9-fold (0.46 log units) above; measured number outside the range, below it.
By their numbers in this assay, from the lowest: compound 4; then compounds 2 and 1 (each within the scatter of the next); then compound 3.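

In this assay, the exchange on a saturated chain carbon, four bonds along the chain from an aromatic nitrogen, gives a 2.5-fold lower number from compound 2 to compound 4 (0.41 log units; beyond the scatter), so the chain amine end of the series responds to change, which the earlier step on the aromatic nitrogen could not show. The step joins two changes: the piperidin-1-yl ring gives way to an open dimethylamino group, and the amine nitrogen stands further along a longer chain, so neither can be credited separately. Nothing at hand explains the size or direction of this step.

Still open, on these data alone, is which of the two changes carries the step: a dimethylamino group on the shorter chain of compound 2 and a piperidine on the longer chain of compound 4 would separate them. A morpholine ring or a diethylamino group at the chain end would also show how far the trend extends.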